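Sulfamoyl for butyl near the assay limit

The compounds below may be only part of what the source reports. "The series", "measured", "known", "first", "only" and "open" are said of these compounds alone.

In an ADME assay on cells (Fibroblast, Homo sapiens) for inhibition, read by MTT assay, with a stated time of 24 h (a lower number here means a stronger inhibitor, a higher number a weaker inhibitor), compound 1 `O=C(N/N=C/c1ccc2c(c1)no[n+]2[O-])c1ccc(Cl)cc1Cl` gives 38300 nM. Compound 2 `CCCOc1ccc(C(=O)N/N=C/c2ccc3c(c2)no[n+]3[O-])cc1` is reported only as a limit, > 200000 nM. Compound 3 `CCCCc1ccc(C(=O)N/N=C/c2ccc3c(c2)no[n+]3[O-])cc1` is also reported only as a limit, > 200000 nM.

Compound 4 `NS(=O)(=O)c1ccc(C(=O)N/N=C/c2ccc3c(c2)no[n+]3[O-])cc1` differs from compound 3 by one change: sulfamoyl in place of butyl on an aromatic carbon. Among the measured compounds shown here, the only measured step that bears on it is a step that the two limits leave unreadable from compound 2 to compound 3, and that step has no readable size. The remaining guide is the limit of > 200000 nM in this assay, at which 2 of the 3 values shown sit. Only compound 1, at 38300 nM, gives a real number. No clear step is therefore expected, though a move towards a lower number remains possible. The expected change is an at least 1.1-fold lower number from compound 3 to compound 4 (0.07 log units; that floor lies within the scatter). For compound 4 the estimated value is 170000 nM, with an expected range from 50000 nM to 400000 nM.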

Compound 4, half-maximal inhibitory concentration: 60000 nM
Compound 4: the middle estimate sits 2.8-fold (0.45 log units) above what was measured, within the range that was stated.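

In this assay, sulfamoyl in place of butyl gives an at least 3.3-fold lower number from compound 3 to compound 4 (0.52 log units; beyond the scatter). Sulfamoyl in place of propoxy gives an at least 3.3-fold lower number from compound 2 to compound 4 (0.52 log units; beyond the scatter). Until now this position had shown no readable change, since both earlier compounds with a group there are reported as limits and the step between them cannot be read; these new steps are therefore floors rather than exact sizes.

As far as these compounds go, the full size of the sulfamoyl step remains open. So does whether another group at this position, such as a carboxylic acid or an amine, would also give a readable number.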